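The compounds below may be only part of what the source reports. "The series", "measured", "known", "first", "only" and "open" are said of these compounds alone.

In a functional assay on MCF7 cells (Homo sapiens) for cytotoxicity, read by MTT assay, with a stated time of 48 h (on this read-out higher numbers stand for weaker inhibition and lower numbers for stronger inhibition), compound 1 `CC(=NNC(=S)Nc1ccccc1F)c1ccccn1` gives 0.39 nM. It stands level with compound 2 `C/C(=N/NC(=S)Nc1ccccc1F)c1ccccn1` at 0.39 nM and with compound 3 `C/C(=N\NC(=S)Nc1ccccc1F)c1ccccn1` at 0.39 nM. The measured steps are no change at the digits printed from compound 1 to compound 2 (within the scatter), no change at the digits printed from compound 1 to compound 3 (within the scatter) and no change at the digits printed from compound 2 to compound 3 (within the scatter). All that separates these three compounds is how one double bond is drawn, as in the fact that one of compounds 1 and 2 is drawn with a defined configuration and the other without, at the place where they differ, the fact that one of compounds 1 and 3 is drawn with a defined configuration and the other without, at the place where they differ and (the fact that compounds 2 and 3 differ only in the configuration as drawn).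

Compound 4 `CC(=NNC(=S)Nc1ccccc1I)c1ccccn1` keeps the core of compound 1 but carries a different change: iodo in place of fluoro on an aromatic carbon, with iodo in place of fluoro on an aromatic carbon, ortho to a large group. Going by the values given here, none of the measured steps touches this position, so they bear on the change only indirectly, and the data give no direction for it. The estimate therefore stays close to compound 1 at 0.39 nM, with a wide margin on both sides. In this assay, the expected result is a 1.3-fold higher number from compound 1 to compound 4 (0.11 log units; within the scatter), which means no step beyond the scatter. The estimated value for compound 4 is 0.5 nM, within an expected range of 0.1 nM to 2.5 nM.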

Compound 4, half-maximal inhibitory concentration: 4.1 nM
The estimate for compound 4 lay 8.2-fold (0.91 log units) below the measured number, outside the stated range (above it).
By their numbers in this assay, from the lowest: compounds 1, 2 and 3 (each within the scatter of the next); then compound 4.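

In this assay, the aromatic carbon ortho to a large group proves sensitive to what it carries: iodo in place of fluoro gives an 11-fold higher number from compound 1 to compound 4 (1.02 log units; beyond the scatter), a large step towards weaker inhibition. The earlier compounds differed only in how one double bond is drawn and stayed level, whereas this is the first change shown that moves the number beyond the scatter. What the earlier comparisons offer concerns only that double bond and gives no explanation for this step. With only fluoro and iodo shown at this place, it remains open where chloro, bromo, a methoxy group or a plain hydrogen would fall, and whether the numbers would follow any order. Also open, going by these compounds, is whether iodo on another carbon of the same ring would give a step of similar size.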